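The source may report more compounds than this note shows. Statements on the series, on what has been measured and on what is new or still open speak of the compounds shown alone.

Among the measured compounds shown here, in a functional assay on A549 cells (Homo sapiens) for cytotoxicity, read by MTT assay, with a stated time of 72 h (a higher number here means a weaker inhibitor, a lower number a stronger inhibitor), compound 2 `COc1ccc(Nc2nc3ccccc3nc2S(=O)(=O)c2ccc(F)cc2)cc1` gives 4840 nM, the higher of the two numbers measured so far and therefore the weaker result. Compound 1 `Nc1cccc(Nc2nc3ccccc3nc2S(=O)(=O)c2ccc(Br)cc2)c1` gives 1120 nM, and the gap between these two values lies beyond the usual scatter. Compound 3 `Nc1cccc(Nc2nc3ccccc3nc2S(=O)(=O)c2ccc(F)cc2)c1` is compound 2 with 3-aminophenyl in place of 4-methoxyphenyl on a nitrogen on an aromatic ring. For the measured compounds named here, no measured pair of compounds shows this change alone, so any forecast remains loose. Compound 1 also carries 3-aminophenyl and stands lower at 1120 nM, so a moderate fall in the number is expected in this assay. The estimated change is a 2.4-fold lower number from compound 2 to compound 3 (0.38 log units; beyond the scatter). Compound 3 is expected to give about 2000 nM, with an estimated range from 700 nM to 6000 nM.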

Compound 3, half-maximal inhibitory concentration: 6840 nM
Beside the measured number, compound 3's estimate is 3.4-fold (0.53 log units) below it, and the stated range ends below it.
By their numbers in this assay, from the lowest: compound 1; then compounds 2 and 3 (each within the scatter of the next).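

In this assay, 3-aminophenyl in place of 4-methoxyphenyl on a nitrogen on an aromatic ring gives a 1.4-fold higher number from compound 2 to compound 3 (0.15 log units; within the scatter), so with fluoro held constant, this assay does not tell these two groups apart. The first matched pair sharing 3-aminophenyl shows that fluoro in place of bromo on an aromatic carbon gives a 6.1-fold higher number from compound 1 to compound 3 (0.79 log units; beyond the scatter), a modest step that links compound 1's lower number to bromo in this pair, not to 3-aminophenyl alone. No measurement here gives a reason for either step.

From the compounds shown here alone, each change rests on a single pair, so it remains open whether bromo would show the same step alongside 4-methoxyphenyl. The compounds shown also leave open how chloro or a plain hydrogen would compare with bromo and fluoro at that aromatic carbon.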